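Trimethoxybenzoyl hydrazones: halogen pattern change at the benzylidene

A few compounds are considered here, and "the series" means these few. Any claim that something is new, unique, unknown or untested is made for them only; others in the source may bear on it.

For the measured compounds named here, compound 1 `COc1cc(C(=O)N/N=C/c2ccc(F)c(F)c2)cc(OC)c1OC` is one of two compounds measured in a functional assay on PC-3 cells (Homo sapiens) for antiproliferative activity, read by MTT assay, tested at 5 uM; a higher number here means a stronger effect of the compound at the concentration tested, a lower number a weaker effect. In this assay compound 1 gives 43.7%, the lower of the two numbers. Compound 2 `COc1cccc(/C=N/NC(=O)c2cc(OC)c(OC)c(OC)c2)c1OC` is the nearer comparison; in this assay compound 2 gives 67%, a gap to compound 1 that lies beyond the usual scatter. Compound 3 `COc1cc(C(=O)N/N=C/c2c(Cl)cccc2Cl)cc(OC)c1OC` is not yet measured. The change from compound 1 to compound 3 is 2,6-dichlorophenyl in place of 3,4-difluorophenyl on a carbon with a double bond to nitrogen. Going by the values given here, no step between measured compounds covers such a change, so the direction is open; the step of a number 1.3 percentage points higher from compound 1 to compound 3 (within the scatter) is expected to be small, likely not beyond the scatter. For compound 3 the value in this assay is estimated at 45%, with a range from 20% to 70%.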

Compound 3, a percentage reported as inhibition, at one concentration (the size of the read-out at that concentration, not a potency): 52.1%
Estimate against measurement, compound 3: 7.1 percentage points below; the range from low to high includes it.
By their numbers in this assay, from the lowest: compounds 1 and 3 (each within the scatter of the next); then compound 2.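

In this assay, for the compounds shown here, placing 2,6-dichlorophenyl in place of 3,4-difluorophenyl on a carbon with a double bond to nitrogen gives a number 8.4 percentage points higher from compound 1 to compound 3 (within the scatter), the first reading of a change at this position. The two halogen patterns are therefore not separated by this read-out, even though both the halogen and its placement on the ring differ between them. No measurement at hand offers an explanation for this result.

On these data alone, since the halogen and its placement change together in this single step, the contribution of each remains open. Also open, as far as these compounds go, is how this assay would respond at the same position to a ring bearing an amine or a carboxylic acid, or to an unsubstituted phenyl ring, with the rest of the core of compound 1 kept the same.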